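A Trifluoromethyl-to-(Dimethylamino)methyl Swap Toward Compound 3

The compounds below may be only part of what the source reports. "The series", "measured", "known", "first", "only" and "open" are said of these compounds alone.

Compound 2 `CC[C@H](C)[C@H](N)CN(C(=O)[C@@H]1C[C@H]1c1ccccc1)c1ccc(-c2ccc(C(F)(F)F)cc2)cc1` stands at the high end of the two numbers measured in a functional assay for agonist activity at G protein-coupled receptor 88 (Homo sapiens), read by HTRF and cAMP accumulation (on this read-out higher numbers stand for an effect only at larger amounts of compound and lower numbers for an effect already at smaller amounts), giving 340 nM, whereas compound 1 `CC(C)C[C@H](N)CCN(C(=O)[C@@H]1C[C@H]1c1ccccc1)c1ccc(-c2ccccc2)cc1` gives 3 nM in this assay. Compound 3 `CC[C@H](C)[C@H](N)CN(C(=O)[C@@H]1C[C@H]1c1ccccc1)c1ccc(-c2ccc(CN(C)C)cc2)cc1` differs from compound 2 in one place: (dimethylamino)methyl in place of trifluoromethyl on an aromatic carbon. Going by the values given here, no measured pair shows this change, so its effect in this assay is open; a modest move toward a lower number is expected for compound 3, though it may stay within the scatter. The estimate for compound 3 in this assay is 150 nM, ranging from 30 nM to 1500 nM. The expected step is a 2.3-fold lower number from compound 2 to compound 3 (0.36 log units; beyond the scatter).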

Compound 3, half-maximal effective concentration: 460 nM
Beside the measured number, compound 3's estimate is 3.1-fold (0.49 log units) below it; the measured number falls inside the stated range.
By their numbers in this assay, from the lowest: compound 1; then compounds 2 and 3 (each within the scatter of the next).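

In this assay, the exchange of trifluoromethyl for (dimethylamino)methyl on this aromatic carbon, para to a large group, gives a 1.4-fold higher number from compound 2 to compound 3 (0.13 log units; within the scatter). Going by these compounds alone, this is the first measured pair differing in one place, and at this position it does not separate the two groups. Nothing measured here bears on why they read alike. As far as these compounds go, whether a carboxylic acid, a nitrile or a longer amine chain on this carbon would read differently stays open. So does whether this swap would give the same result on the core of compound 1.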